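A few compounds are considered here, and "the series" means these few. Any claim that something is new, unique, unknown or untested is made for them only; others in the source may bear on it.

Measured in an ADME assay on cells (Hepatocyte, Homo sapiens) for metabolic stability, with a stated time of 30 min; a lower number here means that less of the compound is left, a higher number that more of the compound is left:
compound 1 `NC1CCC(CN2CCN(c3cc(=O)c4cc(C(F)(F)F)cc([N+](=O)[O-])c4s3)CC2)CC1`: 83.6%
compound 2 `O=c1cc(N2CCN(CC3CCC(NS(=O)(=O)c4ccccc4)CC3)CC2)sc2c([N+](=O)[O-])cc(C(F)(F)F)cc12`: 90.8%
compound 3 `O=C(OC1CCC(CN2CCN(c3cc(=O)c4cc(C(F)(F)F)cc([N+](=O)[O-])c4s3)CC2)CC1)c1ccncc1`: 1%

Compound 3 stands lowest of the three, with 1% in this assay. Both of its gaps are large: a number 82.6 percentage points lower from compound 1 to compound 3 (beyond the scatter), and a number 89.8 percentage points lower from compound 2 to compound 3 (beyond the scatter). The remaining pair is much closer, with a number 7.2 percentage points higher from compound 1 to compound 2 (within the scatter).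

Compound 4 `O=C(OC1CCC(CN2CCN(c3cc(=O)c4cc(C(F)(F)F)cc([N+](=O)[O-])c4s3)CC2)CC1)c1ccc(C(F)(F)F)cc1` differs from compound 3 in one place: 4-(trifluoromethyl)phenyl in place of pyridin-4-yl on a carbonyl carbon. In words, 4-(trifluoromethyl)phenyl stands in place of pyridin-4-yl on a carbonyl carbon. Both large steps brought in ((pyridin-4-yl)carbonyl)oxy, and compound 4 keeps the oxygen and carbonyl of that group. Among the measured compounds shown here, no measured step changes the aromatic group on that carbonyl, so the evidence here is indirect. For the measured compounds named here, compound 3, at 1%, is the only measured compound with this link, and a number close to it is expected, with no step beyond the scatter. The expected change is a number 5 percentage points higher from compound 3 to compound 4 (within the scatter). Compound 4 is estimated at 6%, with an expected range from 0.5% to 25%.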

Compound 4, percent of the compound remaining: 5.2%
Compound 4: middle estimate off by 0.8 percentage points, on the high side; low and high end bracket the measured number.
By their numbers in this assay, from the lowest: compounds 3 and 4 (each within the scatter of the next); then compounds 1 and 2 (each within the scatter of the next).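

In this assay, among the compounds shown here, the change from pyridin-4-yl to 4-(trifluoromethyl)phenyl on the carbonyl carbon gives a number 4.2 percentage points higher from compound 3 to compound 4 (within the scatter) and is the first measured change to the aromatic group on that carbonyl. The very low number seen with compound 3 is therefore not tied to pyridin-4-yl, since compound 4 keeps the oxygen and carbonyl link and gives a number within the scatter of it with a carbon-only aromatic ring in that place. At this position, the swap of a nitrogen-containing ring for a larger, fluorine-bearing one makes no readable difference.

Still open, from the compounds shown here alone, is whether a saturated alkyl chain or a carboxylic acid on that carbonyl carbon, or an amide nitrogen in place of the oxygen, would keep the number this low. No measurement shown gives a reason for the low numbers of this pair.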